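Furan-2-ylmethyl ester in a pyrrole dicarboxylate series

This account rests on a few compounds, and the source may have more. Where it says the series, first, only, none or still open, it means among the compounds named here.

Among the measured compounds shown here, compound 2 `CCCOC(=O)c1[nH]cc(C(=O)OC(C)(C)C)c1C` gives 75 nM in an assay on CHO cells for inhibition of metabotropic glutamate receptor 1 (Rattus norvegicus) (a lower number here means a stronger inhibitor, a higher number a weaker inhibitor), which is the higher of the two numbers so far; its nearest neighbour is compound 1 `Cc1c(C(=O)OC(C)(C)C)c[nH]c1C(=O)OCC1CC1`, which gives 48 nM in this assay, and the step from one to the other is a 1.6-fold higher number from compound 1 to compound 2 (0.19 log units; within the scatter), so the two cannot be ordered. Compound 3 `Cc1c(C(=O)OC(C)(C)C)c[nH]c1C(=O)OCc1ccco1` differs from compound 2 by furan-2-yl in place of ethyl on a saturated chain carbon bound to an oxygen next to a carbonyl group. For the measured compounds named here, only one step bears on this position in the shared core, and it concerns the same ester carbon: the exchange of cyclopropyl for ethyl there gave a 1.6-fold higher number from compound 1 to compound 2 (0.19 log units; within the scatter). The entering furan-2-yl is larger than either group shown and carries a hydrogen-bond acceptor, for which the data give no precedent, so the expectation rests on the small size of the one known step. Compound 3 is therefore expected to show a 1.3-fold lower number from compound 2 to compound 3 (0.10 log units; within the scatter), with no change beyond the scatter in either direction. The estimate for compound 3 in this assay is 60 nM, with a range from 20 nM to 200 nM.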

Compound 3, half-maximal inhibitory concentration: 1200 nM
Compound 3: middle estimate off by 20-fold (1.30 log units), on the low side; the whole stated range lies below it.
By their numbers in this assay, from the lowest: compounds 1 and 2 (each within the scatter of the next); then compound 3.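

In this assay this position proved far less permissive than the earlier pair suggested: furan-2-yl in place of ethyl gives a 16-fold higher number from compound 2 to compound 3 (1.20 log units; beyond the scatter) and furan-2-yl in place of cyclopropyl gives a 25-fold higher number from compound 1 to compound 3 (1.40 log units; beyond the scatter) on the same saturated chain carbon bound to an oxygen next to a carbonyl group. Both steps lie beyond the scatter, whereas the exchange between cyclopropyl and ethyl gave only a 1.6-fold higher number from compound 1 to compound 2 (0.19 log units; within the scatter) and so left the two compounds unordered; the group on this carbon can therefore change the number strongly, and compound 3 stands clearly apart from compound 1 and compound 2. Nothing available explains the loss seen with furan-2-yl.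

The entering group differs from ethyl at once in its heavy-atom count, its five-membered aromatic ring and its hydrogen-bond acceptor, and the compounds shown do not separate these features. A phenyl or thiophen-2-yl group on the same carbon would bear on the aromatic ring without the ring oxygen, and a tetrahydrofuran-2-yl group would keep the ring oxygen without the aromatic ring.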